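Bromo in place of nitro in compound 1

A few compounds are considered here, and "the series" means these few. Any claim that something is new, unique, unknown or untested is made for them only; others in the source may bear on it.

In a functional assay on KYSE-450 cells (Homo sapiens) for inhibition, read by MTT assay, with a stated time of 48 h (a higher number here means a weaker inhibitor, a lower number a stronger inhibitor), compound 1 (`C/C=C/C(=O)N(Cc1ccc(OC)c([N+](=O)[O-])c1)c1cc(OC)c(OC)c(OC)c1`) gives 510 nM. Within the data shown here, only one other compound has a measured value for comparison: compound 2 (`CCC/C=C/C(=O)N(Cc1ccc(OC)c(O)c1)c1cc(OC)c(OC)c(OC)c1`) gives 57 nM. Compound 1 therefore has the higher number of the two, making it the weaker inhibitor by a margin beyond the scatter. Among the measured compounds shown here, these two compounds differ in more than one place, so no measured pair isolates a single structural change.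

Compound 3 (`C/C=C/C(=O)N(Cc1ccc(OC)c(Br)c1)c1cc(OC)c(OC)c(OC)c1`) has yet to be measured in this assay. It has bromo in place of nitro on an aromatic carbon, ortho to a methoxy group and meta to a large group (bromo in place of nitro on an aromatic carbon). A moderate move toward a lower number is expected, though this rests on thin evidence: compound 2, at 57 nM, shows only that a close relative of compound 1 can reach a much lower number. The estimated change is a 2.3-fold lower number from compound 1 to compound 3 (0.37 log units; beyond the scatter), and a result within the scatter would not be surprising. Compound 3 is expected at 220 nM, with an estimated range of 60 nM to 800 nM.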

Compound 3, half-maximal inhibitory concentration: 10500 nM
Compound 3: middle estimate off by 48-fold (1.68 log units), on the low side; measured number above the stated range.
By their numbers in this assay, from the lowest: compound 2; then compound 1; then compound 3.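

Putting bromo in place of nitro on an aromatic carbon, ortho to a methoxy group and meta to a large group, gives a 21-fold higher number from compound 1 to compound 3 (1.31 log units; beyond the scatter) in this assay. Among these compounds, this is the first pair that differs in one place only, and it shows that the group at this position strongly affects the result: with the rest of compound 1 held fixed, the exchange gives a far weaker inhibitor, a large step in the direction opposite to the one that compound 2 had seemed to allow. Nothing measured here accounts for the size or direction of this step.

As far as these compounds go, whether other groups at this position would stay close to compound 1 at 510 nM or fall close to compound 3 at 10500 nM remains open, for instance an amine, a nitrile or a fluoro group. Also open, from the compounds shown here alone, is whether the same exchange would give a step of similar size with the chain that compound 2 carries in place of the shorter one in compound 1.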